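This account rests on a few compounds, and the source may have more. Where it says the series, first, only, none or still open, it means among the compounds named here.

Measured so far in a functional assay on the whole organism (stomach) with Rattus norvegicus as the target; a lower number here means that less compound is needed, a higher number that more compound is needed for the effect:
compound 1 `C/N=C(\S)CCn1nc(-c2ccccc2)ccc1=O` — 58.5 mg/kg
compound 2 `Cc1cc(=O)n(CCC(=N)S)nc1-c1ccccc1` — > 100 mg/kg
compound 3 `C/N=C(\S)CCn1ncccc1=O` — > 100 mg/kg

Among the compounds with values here, compound 1 is the only member with a number in this assay. The result for compound 2 is a limit of the assay, not a number. The result for compound 3 is likewise a limit. Two of the three results thus sit at the limit of > 100 mg/kg in this assay, at which 2 of the 3 values shown sit.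

Within the data shown here, the one step that can be read off is an at least 1.7-fold higher number from compound 1 to compound 3 (0.23 log units; that floor lies within the scatter); its floor lies within the scatter, so even the removal of the phenyl cannot be called a change beyond the scatter. Among the measured compounds shown here, compound 2 differs from compound 1 in two places at once, and its limit alongside the number for compound 1 gives no step.

Compound 4 `N=C(S)CCCCCn1nc(-c2ccccc2)ccc1=O` carries a group of 6 heavy atoms (4 carbon, 1 nitrogen, 1 sulfur; no ring) in place of a group of 4 heavy atoms (2 carbon, 1 nitrogen, 1 sulfur; no ring), on a saturated chain carbon, two bonds along the chain from an aromatic nitrogen; in words, a group of 6 heavy atoms (4 carbon, 1 nitrogen, 1 sulfur; no ring) in place of a group of 4 heavy atoms (2 carbon, 1 nitrogen, 1 sulfur; no ring), on a saturated chain carbon, two bonds along the chain from an aromatic nitrogen. For the measured compounds named here, no measured step touches this chain or its end group, so nothing anchors the direction. The expected step of a 1.2-fold higher number from compound 1 to compound 4 (0.08 log units; within the scatter) is therefore taken as none beyond the scatter, with a wide range, since two of three results already reached the limit. Compound 4 is expected at 70 mg/kg (range 30 mg/kg to 160 mg/kg).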

Compound 4, dose for half-maximal effect: 23.3 mg/kg
Compound 4: middle estimate off by 3.0-fold (0.48 log units), on the high side; measured number outside the range, below it.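

In this assay, within the data shown here, the exchange of a group of 4 heavy atoms (2 carbon, 1 nitrogen, 1 sulfur; no ring) for a group of 6 heavy atoms (4 carbon, 1 nitrogen, 1 sulfur; no ring), on a saturated chain carbon, two bonds along the chain from an aromatic nitrogen, gives a 2.5-fold lower number from compound 1 to compound 4 (0.40 log units; beyond the scatter) and is the first step that lies beyond the scatter. The two groups differ in heavy atoms and also in hydrogen-bond donors, 1 leaving and 2 entering, and this single comparison cannot separate the chain from its end group. Among these compounds, the results for compound 2 and compound 3 remain limits of the assay, which leaves this chain as the only place with a step readable beyond the scatter: the limit of > 100 mg/kg in this assay, at which 2 of the 4 values shown sit.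

Among the compounds shown here, still open is whether the trend continues with a longer chain, or reverses, as only two chain lengths can be compared here and they carry different end groups. Also open, going by these compounds, is how an amine or a carboxylic acid at the chain end would compare with the end group of compound 4 on the same core.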